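The compounds below may be only part of what the source reports. "The series", "measured", "known", "first", "only" and "open" are said of these compounds alone.

Compound 1 `CCN(CC)CC(=O)Nc1ccc(Nc2nc3cc(OC)ccc3cc2-c2ccc(OC)cc2)cc1`: 17300 nM
Compound 2 `COc1ccc(-c2cc3ccc(OC)cc3nc2Nc2ccc(NC(=O)CN3CCCC3)cc2)cc1`: 6600 nM
Compound 3 `CCN(CC)CC(=O)Nc1ccc(Nc2nc3ccc(OC)cc3cc2-c2ccc(OC)cc2)cc1`: > 50000 nM (a limit of the assay)

Three compounds were measured in a functional assay on MCF7 cells (Homo sapiens) for antiproliferative activity, read by MTT assay, with a stated time of 48 h; a lower number here means a stronger inhibitor, a higher number a weaker inhibitor. In this assay compound 1 gives 17300 nM. Compound 2 differs from compound 1 by pyrrolidin-1-yl in place of diethylamino on a saturated chain carbon bound to a carbonyl carbon, and the step is a 2.6-fold lower number from compound 1 to compound 2 (0.42 log units; beyond the scatter). Compound 3 has the same atoms as compound 1 joined differently; the difference between the two cores is not broken down here. In this assay compound 3 reaches only a limit, > 50000 nM. That is the limit of > 50000 nM in this assay, at which 1 of the 3 values shown sits.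

Compound 4 `COc1ccc(-c2cc3cc(OC)ccc3nc2Nc2ccc(NC(=O)CN3CCCC3)cc2)cc1` has not been measured. It differs from compound 3 by pyrrolidin-1-yl in place of diethylamino on a saturated chain carbon bound to a carbonyl carbon, the same change at the same place as that between compound 1 and compound 2. Compound 3 gives only a limit, > 50000 nM, so the starting point for compound 4 is uncertain. A step of about the size seen as a 2.6-fold lower number from compound 1 to compound 2 (0.42 log units; beyond the scatter) is expected, so the estimated step is an at least 2.0-fold lower number from compound 3 to compound 4 (0.30 log units; that floor lies within the scatter). Compound 4 is estimated at 25000 nM in this assay, with an expected range from 9000 nM to 90000 nM.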

Compound 4, half-maximal inhibitory concentration: 7290 nM
Compound 4: the middle estimate sits 3.4-fold (0.54 log units) above what was measured; measured number below the stated range.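

In this assay, pyrrolidin-1-yl in place of diethylamino goes with a lower number on both cores: a 2.6-fold lower number from compound 1 to compound 2 (0.42 log units; beyond the scatter) on the first, and an at least 6.8-fold lower number from compound 3 to compound 4 (0.83 log units; beyond the scatter) on the second, so the direction of the change carries over in these two pairs. The size of the second step is only a floor, since compound 3 gives a limit and not a number: the limit of > 50000 nM in this assay, at which 1 of the 4 values shown sits. Two pairs therefore show the same direction but do not settle whether the change is worth the same on each core: the same change on two cores in this assay, a 2.6-fold lower number (0.42 log units; beyond the scatter) from compound 1 to compound 2 and an at least 6.8-fold lower number (0.83 log units; beyond the scatter) from compound 3 to compound 4; the limit leaves it open whether they differ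

The compounds shown leave open how other cyclic amines, such as piperidin-1-yl or morpholin-4-yl, would read on the same saturated chain carbon, and whether a longer chain to the amine would shift the number on either core. They also leave open how a carboxylic acid in place of the amine would read in this assay.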